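Fluorophenyl amide isomer in a weak cell-growth series

This account rests on a few compounds, and the source may have more. Where it says the series, first, only, none or still open, it means among the compounds named here.

Measured so far:
compound 1 `O=C(O)C1=Cc2ccccc2OC1(OCc1cc(-c2ccc(F)cc2)no1)C(F)(F)F` — 64200 nM
compound 2 `CCOC(=O)C1=Cc2ccccc2OC1(OCc1cn(CC(=O)Nc2cccc(F)c2)nn1)C(F)(F)F` — > 150000 nM

In a functional assay on MCF7 cells (Homo sapiens) for inhibition, read by MTT assay, with a stated time of 24 h (a lower number here means a stronger inhibitor, a higher number a weaker inhibitor), compound 1 gives 64200 nM. Compound 2 gives no number, only a limit of the assay, > 150000 nM. Compound 2 thus stands at the limit of > 150000 nM in this assay, at which 1 of the 2 values shown sits.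

Compound 3 `CCOC(=O)C1=Cc2ccccc2OC1(OCc1cn(CC(=O)Nc2ccccc2F)nn1)C(F)(F)F` is not yet measured. It differs from compound 2 by 2-fluorophenyl in place of 3-fluorophenyl on an amide-type nitrogen. For the measured compounds named here, with no step between measured compounds to draw on, the expected step of a number no higher from compound 2 to compound 3 (the limit leaves the size open) is none beyond the scatter. Compound 3 is expected at 150000 nM, between 60000 nM and 400000 nM, most likely again as a limit.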

Compound 3, half-maximal inhibitory concentration: 42100 nM
Estimate against measurement, compound 3: 3.6-fold (0.55 log units) above; measured number outside the range, below it.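

On the amide-type nitrogen, 2-fluorophenyl in place of 3-fluorophenyl, with the same atoms joined differently, gives in this assay an at least 3.5-fold lower number from compound 2 to compound 3 (0.55 log units; beyond the scatter). This position therefore responds to an isomer change alone, which neither earlier compound could show. The true size of the step remains open, since compound 2 has only a limit and no number: the limit of > 150000 nM in this assay, at which 1 of the 3 values shown sits.

Open, on these data alone, is how plain phenyl, 4-fluorophenyl or 2-chlorophenyl on the same nitrogen would read against compound 3. Also open, as far as these compounds go, is whether a methoxy group there would keep this gain.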